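Coumarin Ethers: Piperazine Phenyl Substitution and H1 Antagonism

This account rests on a few compounds, and the source may have more. Where it says the series, first, only, none or still open, it means among the compounds named here.

Measured compounds:
- compound 1 `Cc1cc(=O)oc2ccc(OCC(O)CN3CCN(C)CC3)cc12`, 0.006 ug/mL
- compound 2 `CCCNCC(O)COc1ccc2c(-c3ccccc3)cc(=O)oc2c1`, 0.0063 ug/mL
- compound 3 `O=c1cc(-c2ccccc2)c2ccc(OCC(O)CN3CCNCC3)cc2o1`, 0.0063 ug/mL

In a functional assay on ileum for antagonist activity at histamine H1 receptor (Cavia porcellus), tested at 0.5 mg/mL (on this read-out lower numbers stand for an effect already at smaller amounts and higher numbers for an effect only at larger amounts of compound), compound 1 gives 0.006 ug/mL, compound 2 gives 0.0063 ug/mL, and compound 3 gives 0.0063 ug/mL. Compound 3 stands level with compound 2 at the digits shown, and its number differs from that of compound 1 only within the scatter, so the three measured compounds cannot be told apart in this assay.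

Compound 4 `O=c1cc(-c2ccccc2)c2ccc(OCC(O)CN3CCN(c4ccccc4)CC3)cc2o1` differs from compound 3 by phenyl in place of hydrogen on an amine nitrogen in a ring. Among the compounds with values here, only one measured step concerns the amine end of the chain: no change at the digits printed from compound 2 to compound 3 (within the scatter). Within the data shown here, that step exchanged the whole amine for a piperazine ring without effect beyond the scatter; it does not test a phenyl on the ring nitrogen, so no measured step bears directly on the change to compound 4. Compound 4 is therefore expected to show a step of a 1.3-fold higher number from compound 3 to compound 4 (0.10 log units; within the scatter) in this assay, no more than the scatter in either direction. The estimate for compound 4 is 0.008 ug/mL, with a range from 0.002 ug/mL to 0.03 ug/mL.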

Compound 4, half-maximal effective concentration: 0.0063 ug/mL
Compound 4: the middle estimate sits 1.3-fold (0.10 log units) above what was measured; measured number inside the range.
By their numbers in this assay, from the lowest: compounds 1, 2, 3 and 4 (each within the scatter of the next).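

In this assay, phenyl in place of hydrogen on an amine nitrogen in a ring gives no change at the digits printed from compound 3 to compound 4 (within the scatter). The earlier step exchanged one whole amine for another, whereas this one adds 6 heavy atoms, as one six-membered aromatic ring of carbon only, at the ring nitrogen, so this position now has a measured result and a group of this size there leaves the read-out within the scatter. Nothing available accounts for this outcome.

The compounds shown leave open whether a benzyl group, an acetyl group or a phenyl ring carrying a carboxylic acid on the same nitrogen would also leave the read-out level. They also leave open whether phenyl at this nitrogen would read the same on the core of compound 1.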